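The compounds below may be only part of what the source reports. "The series", "measured", "known", "first", "only" and "open" are said of these compounds alone.

Compound 3 `CC(C)(C)c1ccc(-n2nnnc2SCC(=O)Nc2ccc(S(C)(=O)=O)cc2Cl)c(Cl)c1` stands highest among the three compounds measured in an in vitro ADME assay on microsomes from liver (Homo sapiens) for metabolic stability (on this read-out lower numbers stand for a shorter-lived compound and higher numbers for a longer-lived compound), at 0.75 h. In this assay compound 1 `O=C(CSc1nnnn1-c1cccc2ccccc12)Nc1ccccc1[N+](=O)[O-]` gives 0.05 h, and compound 2 `Cc1ccc(-n2nnnc2SCC(=O)Nc2ccccc2Cl)c(Cl)c1` gives 0.0333 h; both sit below compound 3 by gaps well beyond the usual scatter. Compound 4 `CC(C)(C)c1ccc(-n2nnnc2SCC(=O)Nc2ccc(-c3ccc(CC(=O)O)cc3)cc2Cl)c(Cl)c1` has not yet been measured. It differs from compound 3 in one place: 4-(carboxymethyl)phenyl in place of methylsulfonyl on an aromatic carbon. For the measured compounds named here, no measured pair shows what such a change does, so there is no step to lean on. In this assay compound 4 is expected to give 0.9 h, within a range of 0.3 h to 2.5 h. The estimated step from compound 3 to compound 4 is a 1.2-fold higher number from compound 3 to compound 4 (0.08 log units; within the scatter), and it is not expected to reach beyond the scatter in either direction.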

Compound 4, half-life: 0.383 h
Estimate against measurement, compound 4: 2.3-fold (0.37 log units) above; low and high end bracket the measured number.
By their numbers in this assay, from the lowest: compounds 2 and 1 (each within the scatter of the next); then compounds 4 and 3 (each within the scatter of the next).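

In this assay, the first change measured at this position gives a 2.0-fold lower number from compound 3 to compound 4 (0.29 log units; within the scatter). This aromatic carbon, para to a large group, therefore carries 4-(carboxymethyl)phenyl in place of methylsulfonyl with no step beyond the scatter, even though the entering group brings an extra aromatic ring. No measurement at hand explains this result. Still open, going by these compounds, is how a small group at this position, such as an amine or a nitrile, would read. On these data alone, whether this change would give a similar step on another core also remains unknown.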